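The source may hold more compounds than are shown below. What is called first, only, known or untested is meant among the compounds shown, and "the series" means these compounds.

In an in vitro assay on HEK385-7 cells for displacement of a labelled ligand from prostaglandin D2 receptor 2 (Homo sapiens) (on this read-out higher numbers stand for weaker inhibition and lower numbers for stronger inhibition), compound 1 `O=C(O)Cc1sc(C(c2ccccc2)c2ccc(Cl)cc2)nc1-c1ccc(Cl)cc1` gives 45 nM, compound 2 `COc1ccc(C(c2ccccc2)c2nc(-c3ccc(Cl)cc3)c(CC(=O)O)s2)cc1` gives 8.4 nM and compound 3 `O=C(O)Cc1sc(C(c2ccc(F)cc2)c2ccc(F)cc2)nc1-c1cccc(F)c1` gives 1.4 nM, the lowest of the three numbers shown. Going by the values given here, the only measured single change, a 5.4-fold lower number from compound 1 to compound 2 (0.73 log units; beyond the scatter), swaps one group for another elsewhere in the molecule and does not bear directly on the step to compound 4 `O=C(O)Cc1sc(C(c2ccc(F)cc2)c2ccc(F)cc2)nc1-c1ccnc(O)c1`, which differs from compound 3 by 2-hydroxypyridin-4-yl in place of 3-fluorophenyl on an aromatic carbon. Among the compounds with values here, no measured step anchors this change, so the expectation rests on the level of compound 3 alone and is uncertain. Compound 4 is expected to show a 3.6-fold higher number from compound 3 to compound 4 (0.55 log units; beyond the scatter), a modest weakening that is plausible but not established. The estimate for compound 4 is 5 nM, within a range from 1 nM to 30 nM.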

Compound 4, half-maximal inhibitory concentration: 68 nM
Estimate against measurement, compound 4: 14-fold (1.13 log units) below, and the stated range ends below it.
By their numbers in this assay, from the lowest: compound 3; then compound 2; then compounds 1 and 4 (each within the scatter of the next).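

The change from 3-fluorophenyl to 2-hydroxypyridin-4-yl, on the aromatic carbon next to the ring nitrogen, gives a 49-fold higher number from compound 3 to compound 4 (1.69 log units; beyond the scatter) in this assay and so weakens inhibition. This position therefore does not treat all six-membered aromatic rings alike, even when the heavy-atom count stays the same. Nothing measured here accounts for the step. The compounds shown leave open whether a plain pyridin-4-yl, without the hydroxy group, or a 3-hydroxyphenyl, without the ring nitrogen, would keep the lower number of compound 3.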